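Acyl for trifluoromethyl on a weak series

The source may report more compounds than this note shows. Statements on the series, on what has been measured and on what is new or still open speak of the compounds shown alone.

Measured in a functional assay on HL-60 cells (Homo sapiens) for inhibition, read by MTT assay, with a stated time of 72 h; a higher number here means a weaker inhibitor, a lower number a stronger inhibitor:
- compound 1 `CC(=O)c1ccc(N2CCN(C(=O)c3oc(C)nc3-c3ccccc3)CC2)cc1`: "not active" (no number reported)
- compound 2 `Cc1nc(-c2ccccc2)c(C(=O)N2CCN(c3ccc(C(F)(F)F)cc3)CC2)o1`: > 1000 nM (a limit, not a number)

Neither compound gives a number to work from. Compound 2 stands only at a limit of this assay, with > 1000 nM as its entry. Compound 1 is reported as "not active" (no number reported). Among the measured compounds shown here, no step between measured compounds exists, so the size of any structural effect remains unknown.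

The next compound is compound 3 `Cc1nc(-c2ccccc2)c(C(=O)N2CCN(c3ccc(C(=O)C(C)C)cc3)CC2)o1`, with isopropylcarbonyl in place of trifluoromethyl on an aromatic carbon, para to a large group: isopropylcarbonyl in place of trifluoromethyl on an aromatic carbon.

No step beyond the scatter is expected in this assay, in either direction. This expectation rests on compound 2, whose entry of > 1000 nM is a limit. The step expected is a step that the limit leaves unreadable from compound 2 to compound 3. A further report of a limit, with no number, would also be in line with expectation. For compound 3 the estimated value is 1800 nM, with an expected range from 500 nM to 8000 nM.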

Compound 3, half-maximal inhibitory concentration: "not active" (no number reported)
No number was reported for compound 3; there is nothing to compare the estimate with.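

In this assay compound 3 gives "not active" (no number reported), so no step can be read from compound 2 to compound 3, nor between these and compound 1. Compound 2 stands at a limit: the limit of > 1000 nM in this assay, at which 1 of the 3 values shown sits.

The compounds shown leave open whether isopropylcarbonyl and trifluoromethyl differ at all in this assay, and what potency the shared core can reach.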